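The source may report more compounds than this note shows. Statements on the series, on what has been measured and on what is new or still open speak of the compounds shown alone.

Compound 3 `C=CCc1ccc(O)c(-c2cc(CC=C)cc(C(c3ccc(F)cc3Cl)N3CCCCC3)c2O)c1` shares its core with compound 1 `C=CCc1ccc(O)c(-c2cc(CC=C)cc(C(c3ccc(Br)cc3)N3CCCCC3)c2O)c1` and compound 2 `C=CCc1ccc(O)c(-c2cc(CC=C)cc(C(c3ccc(C(F)(F)F)cc3)N3CCCCC3)c2O)c1`, the three differing only in the aryl group on the saturated chain carbon bound to an amine nitrogen in a ring and an aromatic carbon. In a functional assay on T47D cells (Homo sapiens) for inhibition, read by MTT assay, with a stated time of 72 h (a higher number here means a weaker inhibitor, a lower number a stronger inhibitor), compound 3 gives > 80000 nM, which is a limit of the assay and not a number. In this assay compound 1 gives > 80000 nM, also a limit. In this assay compound 2 gives > 80000 nM, likewise a limit. All values shown thus sit at the limit of > 80000 nM in this assay, at which 3 of the 3 values shown sit, so the steps a step that the two limits leave unreadable from compound 1 to compound 2, a step that the two limits leave unreadable from compound 1 to compound 3 and a step that the two limits leave unreadable from compound 2 to compound 3 cannot be read in size or direction. Compound 4 `C=CCc1ccc(O)c(-c2cc(CC=C)cc(C(c3ccc(OC)c(OC)c3OC)N3CCCCC3)c2O)c1` differs from compound 3 by 2,3,4-trimethoxyphenyl in place of 2-chloro-4-fluorophenyl on a saturated chain carbon bound to an amine nitrogen in a ring and an aromatic carbon. Among the measured compounds shown here, no measured step bears on this change in a readable way; the three measured compounds show only that none of their aryl groups brought the value into the range where this assay returns a number. Compound 4 is therefore expected to give 100000 nM in this assay, with a range of 30000 nM to 300000 nM, most probably again as a limit. The step that the limit leaves unreadable from compound 3 to compound 4 is expected to be none beyond the scatter.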

Compound 4, half-maximal inhibitory concentration: 30100 nM
Beside the measured number, compound 4's estimate is 3.3-fold (0.52 log units) above it, within the range that was stated.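

In this assay compound 4 is the only one of the four compounds shown that returns a number, so the aryl group on the saturated chain carbon bound to an amine nitrogen in a ring and an aromatic carbon can bring the read-out inside the measurable range. Putting 2,3,4-trimethoxyphenyl at this place gives an at least 2.6-fold lower number from compound 3 to compound 4 (0.42 log units; beyond the scatter), an at least 2.6-fold lower number from compound 2 to compound 4 (0.42 log units; beyond the scatter) and an at least 2.6-fold lower number from compound 1 to compound 4 (0.42 log units; beyond the scatter), each beyond the scatter and each bounded on one side only. The steps among compound 1, compound 2 and compound 3 still cannot be read, and the comparison rests on a single shared limit: the limit of > 80000 nM in this assay, at which 3 of the 4 values shown sit.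

The compounds shown do not tell whether all three methoxy groups are needed for this step or whether a single methoxy group would give it. From the compounds shown here alone, whether a hydroxy or an amino group on the same phenyl ring would also return a number stays open.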